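A few compounds are considered here, and "the series" means these few. Any claim that something is new, unique, unknown or untested is made for them only; others in the source may bear on it.

In a physicochemical assay for solubility, read by nephelometry, measured as kinetic solubility (on this read-out higher numbers stand for higher solubility and lower numbers for lower solubility), compound 3 `CCC/N=C1\S/C(=C\c2ccc(C(=O)OCCCO)cc2)C(=O)N1c1ccccc1O` gives 183000 nM and compound 2 `CCC/N=C1\S/C(=C\c2ccc(OC[C@H](O)CO)c(Cl)c2)C(=O)N1c1ccccc1O` gives 219000 nM so these two values lie within the scatter of each other. Compound 1 `CCC/N=C1\S/C(=C\c2ccc(C(=O)NCCO)cc2)C(=O)N1c1ccccc1C` gives > 250000 nM as a limit of the assay and not a number. The structural change to compound 4 `CCC/N=C1\S/C(=C\c2ccc(C(=O)OCc3oc(=O)oc3C)cc2)C(=O)N1c1ccccc1O` is a group of 7 heavy atoms (4 carbon, 3 oxygen; one five-membered aromatic ring with 2 hetero atoms) in place of a group of 3 heavy atoms (2 carbon, 1 oxygen; no ring), on a saturated chain carbon bound to an oxygen next to a carbonyl group and nothing else in the molecule differs. Going by the values given here, no measured pair shows a change of this kind, so the expectation rests on the structural difference alone and stays loose. A clear drop in this assay beyond the scatter is expected, and the estimated step is a 4.6-fold lower number from compound 3 to compound 4 (0.66 log units; beyond the scatter) in this series. For compound 4 the estimated value is 40000 nM with an expected range from 10000 nM to 150000 nM in this read-out.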

Compound 4, solubility: 79000 nM
Beside the measured number, compound 4's estimate is 2.0-fold (0.30 log units) below it; the range from low to high includes it.
By their numbers in this assay, from the lowest: compound 4; then compounds 3 and 2 (each within the scatter of the next). At a limit, above all of these: compound 1.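

Going by these compounds alone, this is the first step read on a saturated chain carbon bound to an oxygen next to a carbonyl group: in this assay, the five-membered aromatic ring group in place of 2-hydroxyethyl gives a 2.3-fold lower number from compound 3 to compound 4 (0.36 log units; beyond the scatter). Ring, size and hydrogen-bond donors (1 leaving, 0 entering) all change in this one step, so it cannot separate them. Nothing measured here accounts for the step. As far as these compounds go, whether a methyl, a longer chain or an amine at this place would give a similar number in this assay stays open.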